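The source may report more compounds than this note shows. Statements on the series, on what has been measured and on what is new or still open speak of the compounds shown alone.

Of the compounds shown here, three of one family have been measured in a functional assay on PC-3 cells (Homo sapiens) for inhibition, read by MTT assay, with stated times of 18 h and 4 h; on this read-out higher numbers stand for weaker inhibition and lower numbers for stronger inhibition. Compound 1 `CCCCCCCCCCCCCCCCOP(=O)(O)OCCSC(=S)N1CCCCCC1` carries a long saturated chain on the phosphate oxygen and a seven-membered nitrogen ring on the thiocarbonyl carbon, and in this assay compound 1 gives 32100 nM. Compound 2 `CCCCCCOP(=O)(O)OCCSC(=S)N1CCCCCC1` keeps the same ring but has a much shorter chain. For compound 2 the assay reports only a limit, > 100000 nM, not a number. Compound 3 `CCCCCCOP(=O)(O)OCCSC(=S)N1CCCCC1` shares the short chain of compound 2 and differs from it in the ring: piperidin-1-yl in place of azepan-1-yl on a thiocarbonyl carbon. For compound 3 too the assay reports only a limit, > 100000 nM.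

Lengthening the chain is the one change already seen in measured compounds: decyl in place of hydrogen on a saturated chain carbon, six bonds along the chain from an oxygen on an unsaturated carbon. That change gave an at least 3.1-fold lower number from compound 2 to compound 1 (0.49 log units; beyond the scatter). The ring swap itself gave a step that the two limits leave unreadable from compound 2 to compound 3; its size cannot be read because of the limit of > 100000 nM in this assay, at which 2 of the 3 values shown sit.

Compound 4 `CCCCCCCCCCCCCCCCOP(=O)(O)OCCSC(=S)N1CCCCC1` has not yet been measured. It stands to compound 3 as compound 1 stands to compound 2: decyl in place of hydrogen on a saturated chain carbon, six bonds along the chain from an oxygen on an unsaturated carbon. The place of the change is described in the same words in both pairs, so this is the same change made on the core of compound 3. Beside the measured at least 3.1-fold lower number from compound 2 to compound 1 (0.49 log units; beyond the scatter), the step from compound 3 to compound 4 is expected to be an at least 2.8-fold lower number from compound 3 to compound 4 (0.45 log units; beyond the scatter), resting on the measured change from compound 2 to compound 1 and on the value of compound 1, 32100 nM. Compound 4 is therefore estimated at 35000 nM, with a plausible range from 12000 nM to 100000 nM.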

Compound 4, half-maximal inhibitory concentration: 34300 nM
Compound 4: middle estimate off by 1.0-fold (0.01 log units), on the high side; the measured number falls inside the stated range.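

In this assay, the decyl change made on the core of compound 3 gives an at least 2.9-fold lower number from compound 3 to compound 4 (0.46 log units; beyond the scatter), so a change first seen on one core also lowers the number on a second core. The two steps point the same way, but this does not show that the change is worth the same amount on both cores, and two cores are too few to promise the same result on a third: the same change on two cores in this assay, an at least 3.1-fold lower number (0.49 log units; beyond the scatter) from compound 2 to compound 1 and an at least 2.9-fold lower number (0.46 log units; beyond the scatter) from compound 3 to compound 4; the limit leaves it open whether they differ The ring swap can be read only among the long-chain compounds, where it gives a 1.1-fold higher number from compound 1 to compound 4 (0.03 log units; within the scatter), so the two rings cannot be told apart on that chain, while the same swap among the short-chain compounds stays unreadable: the limit of > 100000 nM in this assay, at which 2 of the 4 values shown sit.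

Still open, on these data alone, is whether a longer chain, such as octadecyl, would lower the number further on either core, or whether the trend stops once the chain passes a certain length. Also open, as far as these compounds go, is whether a morpholine ring on the thiocarbonyl carbon, or an amine or a carboxylic acid on the chain, would leave the step seen with the decyl change intact.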